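A 4-hydroxyphenyl group enters compound 1

The compounds below may be only part of what the source reports. "The series", "measured", "known", "first", "only" and "open" are said of these compounds alone.

In an in vivo ADME assay on the whole organism (Cavia porcellus) (on this read-out lower numbers stand for a shorter-lived compound and higher numbers for a longer-lived compound), compound 1 (`C/C=C/C(NC(=O)c1ccc(C(=N)N)cc1)C(C)(C)C(=O)N1CCC(CC(=O)O)CC1`) gives 0.933 h. Compound 2 (`CC(C)CC(NC(=O)c1ccc(C(=N)N)cc1)C(C)(C)C(=O)N1CCC(CC(=O)O)CC1`) gives 0.917 h and compound 3 (`CCCCCC(NC(=O)c1ccc(C(=N)N)cc1)C(C)(C)C(=O)N1CCC(CC(=O)O)CC1`) gives 0.517 h, so both stand within the scatter of compound 1. Compound 4 (`CC(C)(C(=O)N1CCC(CC(=O)O)CC1)C(NC(=O)c1ccc(C(=N)N)cc1)c1ccc(O)cc1`) carries 4-hydroxyphenyl in place of prop-1-en-1-yl on a saturated chain carbon bound to an amide-type nitrogen and a saturated chain carbon. Two measured changes at that carbon bear on this: isobutyl gives a 1.0-fold lower number from compound 1 to compound 2 (0.01 log units; within the scatter), and pentyl gives a 1.8-fold lower number from compound 1 to compound 3 (0.26 log units; within the scatter). Neither entering group has an aromatic ring, so they are only a loose guide. Going by these two steps, the expected change is a 1.3-fold lower number from compound 1 to compound 4 (0.12 log units; within the scatter), with no step beyond the scatter expected. Compound 4 is estimated at 0.7 h, with an expected range of 0.35 h to 1.4 h.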

Compound 4, half-life: 1.05 h
For compound 4 the middle estimate is 1.5-fold (0.18 log units) below the measured one, and the stated range covers the measured number.
By their numbers in this assay, from the lowest: compounds 3, 2, 1 and 4 (each within the scatter of the next, the first and the last beyond it).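

In this assay an aromatic ring at this carbon leaves the number within the scatter of the open-chain groups of compound 1 and compound 2: the change gives a 1.1-fold higher number from compound 1 to compound 4 (0.05 log units; within the scatter) and a 1.1-fold higher number from compound 2 to compound 4 (0.06 log units; within the scatter). Only the comparison with pentyl passes the scatter, and modestly, with a 2.0-fold higher number from compound 3 to compound 4 (0.31 log units; beyond the scatter). Nothing measured here accounts for these steps.

On these data alone, what a plain phenyl or a 4-methoxyphenyl group would give at this carbon stays open, so the share of the hydroxyl and that of the ring in compound 4 cannot be separated. As far as these compounds go, how an aminoalkyl chain would behave at the same carbon is equally open.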